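Phenyl for Decyl on the Sulfur-Bound Carbon

The compounds below may be only part of what the source reports. "The series", "measured", "known", "first", "only" and "open" are said of these compounds alone.

Compound 1: `CCCCSC(=S)C1=C(Nc2ccc(Cl)cc2Cl)CC(C)(C)CC1=O` — > 20 ug/mL
Compound 2: `CCCCCCCCCCCSC(=S)C1=C(Nc2ccc(Cl)cc2Cl)CC(C)(C)CC1=O` — > 20 ug/mL

In a functional assay on PBMC cells (Homo sapiens) for inhibition, read by ELISA, with a stated time of 18 h (on this read-out lower numbers stand for stronger inhibition and higher numbers for weaker inhibition), compound 1 gives > 20 ug/mL, which is a limit of the assay and not a number. Compound 2 gives > 20 ug/mL, likewise a limit. For the measured compounds named here, the only measured step is a step that the two limits leave unreadable from compound 1 to compound 2, and its size cannot be read because both values sit at the limit of > 20 ug/mL in this assay, at which 2 of the 2 values shown sit. Compound 2 therefore stands at the assay limit, without a measured number.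

Compound 3, `CC1(C)CC(=O)C(C(=S)SCc2ccccc2)=C(Nc2ccc(Cl)cc2Cl)C1`, differs from compound 2 by phenyl in place of decyl on a saturated chain carbon bound to a sulfur. Going by the values given here, no measured step bears on this change: the one step available is unreadable, so no direction or size can be drawn from it. Compound 3 is expected to remain near the limit, with an estimate of 30 ug/mL and a range from 8 ug/mL to 100 ug/mL. That estimate means an expected step that the limit leaves unreadable from compound 2 to compound 3, which cannot be tested against any readable measured step.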

Compound 3, half-maximal inhibitory concentration: > 20 ug/mL
Compound 3 ended at the assay's limit; the forecaster's own chance of this, stated with the estimate: 70%; the middle value does not contradict the limit.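

For the compounds shown here, compound 1, compound 2 and compound 3 all sit at a limit of the assay and not at a number, so no step among them can be read: the limit of > 20 ug/mL in this assay, at which 3 of the 3 values shown sit.

The compounds shown leave open whether any group on the saturated chain carbon bound to a sulfur gives a readable value in this assay at all.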